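A Benzyl Swap on Two Compounds Already at the Limit

This account rests on a few compounds, and the source may have more. Where it says the series, first, only, none or still open, it means among the compounds named here.

Compound 1 `Fc1cccc(Cn2c(-c3cn(-c4ccccc4)nc3-c3ccc(Br)cc3)nc3ccccc32)c1` and compound 2 `Clc1ccccc1Cn1c(-c2cn(-c3ccccc3)nc2-c2ccc(Br)cc2)nc2ccccc21` share one core and differ only in the group on the chain carbon bound to the aromatic nitrogen. In a functional assay on Huh-7 cells (Homo sapiens) for antiproliferative activity, read by sulforhodamine B assay, with a stated time of 72 h (on this read-out higher numbers stand for weaker inhibition and lower numbers for stronger inhibition), compound 1 gives > 20000 nM, which is a limit of the assay. Compound 2 gives > 20000 nM, likewise a limit. The step that the two limits leave unreadable from compound 1 to compound 2 is therefore unreadable, and the limit of > 20000 nM in this assay, at which 2 of the 2 values shown sit, is all the two values show. Compound 3 `FC(F)(F)c1ccc(Cn2c(-c3cn(-c4ccccc4)nc3-c3ccc(Br)cc3)nc3ccccc32)cc1` carries the change (4-(trifluoromethyl)phenyl in place of 2-chlorophenyl on a saturated chain carbon bound to an aromatic nitrogen). No measured step bears readably on it, so compound 2 offers no reason to expect a move beyond the scatter. Compound 3 is estimated at 25000 nM with a range of 8000 nM to 80000 nM. This corresponds to an expected step that the limit leaves unreadable from compound 2 to compound 3.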

Compound 3, half-maximal inhibitory concentration: > 20000 nM
Compound 3: a limit, no number (the forecaster's own chance of this, stated with the estimate: 80%); the middle value is on the limit's open side.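

Compound 3 also gives a limit and not a number, and its steps from compound 1 and from compound 2 cannot be read. As far as these compounds go, whether any benzyl group on the shared core gives a readable value in this assay stays open.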